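Moving from a methyl to three methoxy groups on the amide

The source may report more compounds than this note shows. Statements on the series, on what has been measured and on what is new or still open speak of the compounds shown alone.

Measured so far:
Compound 1, `N#CC1=C(NC(=O)c2ccccc2)N(c2ccc(S(N)(=O)=O)cc2)C2=C(C(=O)CCC2)C1c1ccc(Cl)cc1Cl`: 60%
Compound 2, `Cc1ccc(C(=O)NC2=C(C#N)C(c3ccc(Cl)cc3Cl)C3=C(CCCC3=O)N2c2ccc(S(N)(=O)=O)cc2)cc1`: 30%

Both compounds were tested in a functional assay on Ehrlich cells (Mus musculus) for cytotoxicity, read by trypan blue exclusion, with a stated time of 2 h, tested at 25 ug/mL; on this read-out higher numbers stand for a stronger effect at the one concentration tested and lower numbers for a weaker effect. Compound 1 gives 60%, and compound 2 gives 30%. Going by the values given here, the single measured step, a number 30 percentage points lower from compound 1 to compound 2 (beyond the scatter), arises from a methyl in place of hydrogen on an aromatic carbon. Compound 2 thus stands lowest of the two numbers shown, with compound 1 as its only neighbour.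

Compound 3, `COc1cc(C(=O)NC2=C(C#N)C(c3ccc(Cl)cc3Cl)C3=C(CCCC3=O)N2c2ccc(S(N)(=O)=O)cc2)cc(OC)c1OC`, has not yet been measured. It differs from compound 2 in one place: 3,4,5-trimethoxyphenyl in place of 4-methylphenyl on a carbonyl carbon. Among the compounds with values here, the only measured step, a number 30 percentage points lower from compound 1 to compound 2 (beyond the scatter), also changed a substituent on this same aromatic ring, and it was modest in size; but it concerned a methyl, not methoxy groups, so it bears only loosely on the new change. Within the data shown here, with no step that matches it directly, the expectation for compound 3 in this assay is a number close to that of compound 2, with the expected step of no change at the digits printed from compound 2 to compound 3 (within the scatter) lying within the scatter. Compound 3 is therefore estimated at 30%, with a range from 10% to 55%.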

Compound 3, a percentage reported as activity, at one concentration (the size of the read-out at that concentration, not a potency): 20%
Compound 3: the middle estimate sits 10 percentage points above what was measured; the range from low to high includes it.
By their numbers in this assay, from the lowest: compounds 3 and 2 (each within the scatter of the next); then compound 1.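

In this assay, placing 3,4,5-trimethoxyphenyl instead of 4-methylphenyl on the carbonyl carbon gives a number 10 percentage points lower from compound 2 to compound 3 (within the scatter), so this much larger group, with its three methoxy groups, cannot be told apart from the single methyl at this position. Measured against the unsubstituted phenyl, the same group gives a number 40 percentage points lower from compound 1 to compound 3 (beyond the scatter), which shows that both substituted rings in this small set, in compound 2 and compound 3, stand clearly apart from the plain phenyl of compound 1, while the kind of substituent makes no readable difference between them. Nothing available explains why the plain phenyl stands apart from the two substituted rings.

The compounds shown leave open whether any substituent on this ring gives the same result, or whether a ring carrying an amine, a carboxylic acid or a single fluorine would stay closer to compound 1. They also leave open whether a different group on the carbonyl carbon, such as a longer alkyl chain in place of the aromatic ring, would hold the read-out of compound 1.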